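The compounds below may be only part of what the source reports. "The series", "measured", "known", "first", "only" and "open" are said of these compounds alone.

Measured so far in a functional assay on the whole organism (Tail, strain ICR) with Mus musculus as the target, in the tail flick test, with a stated time of 90 min, at a dose of 25 umol/kg by the oral route; a lower number here means a weaker effect, a higher number a stronger effect of the compound at the dose given:
compound 1, `O=C(O)[C@@H]1CCCN1C(=O)CN(c1nc(Cl)nc2[nH]cnc12)C1CC1`: 26%
compound 2, `C[C@H](NC(=O)CN(c1nc(Cl)nc2[nH]cnc12)C1CC1)C(=O)O`: 43.5%
compound 3, `N=C(N)NCCC[C@H](NC(=O)CN(c1nc(Cl)nc2[nH]cnc12)C1CC1)C(=O)O`: 27.6%

Compound 3 stands second of the three numbers in this assay. Its value and that of compound 1 lie within the scatter of each other, so no order between them can be read; compound 2 stands apart, giving a number 15.9 percentage points lower from compound 2 to compound 3 (beyond the scatter) on the way from compound 2 to compound 3.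

Compound 4, `CC(C)[C@H](NC(=O)CN(c1nc(Cl)nc2[nH]cnc12)C1CC1)C(=O)O`, has not yet been measured. It differs from compound 3 thus: a group of 3 heavy atoms (3 carbon; no ring) in place of a group of 7 heavy atoms (4 carbon, 3 nitrogen; no ring), on a saturated chain carbon bound to an amide-type nitrogen and a carbonyl carbon

Among the measured compounds shown here, the step that bears most directly on this change is the one from compound 2 to compound 3, a number 15.9 percentage points lower from compound 2 to compound 3 (beyond the scatter), where the same group of 6 heavy atoms entered in place of a hydrogen atom; compound 4 removes that group again and carries isopropyl instead. The step from compound 1 to compound 2, a number 17.5 percentage points higher from compound 1 to compound 2 (beyond the scatter), shows that a smaller substituent at this position went with the higher number of the series. For the measured compounds named here, on these two steps a modest rise from compound 3 to compound 4 is expected, a number 12.4 percentage points higher from compound 3 to compound 4 (beyond the scatter), towards the level of compound 2, though with only three compounds the range must stay wide. Compound 4 is therefore estimated at 40% in this assay, expected between 25% and 55%.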

Compound 4, a percentage reported as activity, at one dose (the size of the read-out at that dose, not a potency): 30.3%
The estimate for compound 4 lay 9.7 percentage points above the measured number, and the stated range covers the measured number.
By their numbers in this assay, from the lowest: compounds 1, 3 and 4 (each within the scatter of the next); then compound 2.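

In this assay, a number 13.2 percentage points lower from compound 2 to compound 4 (beyond the scatter), so isopropyl in place of methyl on this saturated chain carbon bound to an amide-type nitrogen and a carbonyl carbon is enough to move the number away from that of compound 2. With a number 2.7 percentage points higher from compound 3 to compound 4 (within the scatter), isopropyl and the group of 7 heavy atoms cannot be told apart here, so the nitrogen atoms and hydrogen-bond donors counted in that group are not needed for the number seen with compound 3. Among the compounds shown here, with a number 4.3 percentage points higher from compound 1 to compound 4 (within the scatter), compound 4 also cannot be told apart from compound 1, which leaves compound 2, with its methyl, as the only one of the four compounds that stands apart in this assay.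

Still open, going by these compounds, is whether the higher number belongs to methyl alone or would also appear with a hydrogen atom or an ethyl group at this place. On these data alone, it is also open whether a longer chain ending in an amine or a carboxylic acid would stay with compounds 1, 3 and 4 or move towards compound 2. Nothing available here bears on the reason for these numbers.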